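Phenoxy to benzyl on the open-chain arm of compound 1

The source may report more compounds than this note shows. Statements on the series, on what has been measured and on what is new or still open speak of the compounds shown alone.

Measured in an assay on isolated protein for inhibition of Myeloperoxidase (Homo sapiens), with a stated time of 10 min; on this read-out lower numbers stand for stronger inhibition and higher numbers for weaker inhibition:
compound 1 `Nc1cc(Cc2ccn(Cc3cccc(Oc4ccccc4)c3)n2)c2nn[nH]c2n1` — 44 nM
compound 2 `Nc1cc(C2CCNCc3cccc(c3)OCc3cccc(c3)Cn3cc2cn3)c2nn[nH]c2n1` — 8 nM
compound 3 `Nc1cc(C2CCNC3CCC(CC3)COc3cccc(c3)Cn3cc2cn3)c2nn[nH]c2n1` — 31 nM

In this assay compound 1 has the highest of the three numbers. Against compound 3 the gap lies within the scatter, so the two are not separable. Compound 2 gives a number well below that of compound 1, a gap beyond the scatter; compound 2 and compound 3 are macrocycles, while compound 1 and the new compound 4 `Nc1cc(Cc2ccn(Cc3cccc(Cc4ccccc4)c3)n2)c2nn[nH]c2n1` carry an open arm. Compound 4 differs from compound 1 by one change: benzyl in place of phenoxy on an aromatic carbon. Among the measured compounds shown here, no measured pair shows this change, so nothing here sizes it. The expected step of a 1.1-fold higher number from compound 1 to compound 4 (0.06 log units; within the scatter) is therefore small and not beyond the scatter, with the direction open. Compound 4 is estimated at 50 nM, in the range 20 nM to 130 nM.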

Compound 4, half-maximal inhibitory concentration: 39 nM
For compound 4 the middle estimate is 1.3-fold (0.11 log units) above the measured one; the range from low to high includes it.
By their numbers in this assay, from the lowest: compound 2; then compounds 3, 4 and 1 (each within the scatter of the next).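

Benzyl in place of phenoxy gives a 1.1-fold lower number from compound 1 to compound 4 (0.05 log units; within the scatter) in this assay and so separates neither compound from the other. Among the compounds shown here, on an aromatic carbon, meta to a large group, the arm therefore gives up its one hydrogen-bond acceptor with no step beyond the scatter, which is the first sizing of this change. Nothing at hand accounts for this result. Still open, going by these compounds, is whether an amine, a carboxylic acid or a longer chain at this place would shift the number beyond the scatter.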